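Cytotoxicity notes on two fused bicyclic analogues

This account rests on a few compounds, and the source may have more. Where it says the series, first, only, none or still open, it means among the compounds named here.

Measured so far:
- compound 1 `O=c1n(Cc2nc3ccc(Cl)cn3c2CCCCO)c2cnccc2n1C1CC1`; in an ADME assay on HEp-2 cells (Homo sapiens) for cytotoxicity, read by CCK-8 assay, with a stated time of 6 days (on this read-out higher numbers stand for lower toxicity in this test and lower numbers for higher toxicity in this test), compound 1 gives a limit of > 100000 nM
- compound 2 `O=C(NCCO)c1c(Cn2c(=O)n(C3CC3)c3ccncc32)nc2cc(Cl)ccn12`; in this assay compound 2 gives a limit of > 100000 nM

Compound 2 stands at the top of what this assay reports: its value is a limit of the assay and not a number. Within the data shown here, the only other value shown is a limit as well, so the two compounds cannot be placed in any order relative to each other; both sit at the limit of > 100000 nM in this assay, at which 2 of the 2 values shown sit. Among the measured compounds shown here, no pair of measured compounds differing in one place is available, so no measured step exists.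

Compound 3 `O=c1n(Cc2nc3cc(Cl)ccn3c2NC2CCCCC2)c2cnccc2n1C1CC1` is the next compound to be measured. It differs from compound 2 by cyclohexylamino in place of (2-hydroxyethyl)carbamoyl on an aromatic carbon. With only limits in hand, no size of step can be read from the data, and the expectation for this assay is no change beyond the scatter. Compound 3 is therefore expected to give 100000 nM, within a range of 30000 nM to 300000 nM. This expected value for compound 3 corresponds to a step of a number no higher from compound 2 to compound 3 (the limit leaves the size open), and it rests on the limit reached by compound 2 at > 100000 nM; a reported limit rather than a number is the more likely outcome.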

Compound 3, half-maximal cytotoxic concentration: > 100000 nM
Compound 3 was reported as a limit; the forecaster's own chance of this, stated with the estimate: 70%; the middle value lies on the limit itself.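

In this assay compound 3 gives > 100000 nM, which is a limit and not a number. With compound 2 also reported as a limit, no step can be read between compound 2 and compound 3: the limit of > 100000 nM in this assay, at which 3 of the 3 values shown sit.

The compounds shown leave open at what concentration, if any, compound 1, compound 2 or compound 3 would reach half-maximal cytotoxicity.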